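Methoxy addition on the nitroaryl ketone across two cores

This account rests on a few compounds, and the source may have more. Where it says the series, first, only, none or still open, it means among the compounds named here.

Three enaminone compounds are measured in a functional assay on HeLa cells (Homo sapiens) for antiproliferative activity, read by sulforhodamine B assay, with a stated time of 48 h; on this read-out lower numbers stand for stronger inhibition and higher numbers for weaker inhibition. Compound 1 `COc1cc(C(=O)/C=C\Nc2ccc(-c3nc4cc(OC)c(OC)c(OC)c4s3)cc2C)cc([N+](=O)[O-])c1OC` gives 13100 nM; compound 2 `COc1ccc(C(=O)/C=C\Nc2ccc(-c3nc4cc(OC)c(OC)c(OC)c4s3)cc2C)cc1[N+](=O)[O-]` gives 13400 nM; compound 3 `COc1ccc2nc(-c3ccc(N/C=C\C(=O)c4ccc(OC)c([N+](=O)[O-])c4)cc3)sc2c1` gives 17600 nM. All three values lie within the scatter of one another, so no order among them is read.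

The pair compound 2 and compound 1 differs in one place, (methoxy in place of hydrogen on an aromatic carbon), and the step is a 1.0-fold lower number from compound 2 to compound 1 (0.01 log units; within the scatter). Compound 3 carries a different core from compound 2; the difference between the two cores is not broken down here, and their values simply sit close together.

Compound 4 `COc1ccc2nc(-c3ccc(N/C=C\C(=O)c4cc(OC)c(OC)c([N+](=O)[O-])c4)cc3)sc2c1` is not yet measured. It differs from compound 3 by methoxy in place of hydrogen on an aromatic carbon, the same change as from compound 2 to compound 1, at the same place in the same words. Going by the values given here, because that earlier step was a 1.0-fold lower number from compound 2 to compound 1 (0.01 log units; within the scatter), a step of about the same size is expected here, namely a 1.0-fold lower number from compound 3 to compound 4 (0.02 log units; within the scatter), resting on the single measured precedent in this assay. Compound 4 is accordingly estimated at 17000 nM, with a likely range from 9000 nM to 34000 nM.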

Compound 4, half-maximal inhibitory concentration: 16100 nM
Compound 4: middle estimate off by 1.1-fold (0.02 log units), on the high side; low and high end bracket the measured number.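

In this assay, methoxy in place of hydrogen on an aromatic carbon gives a 1.1-fold lower number from compound 3 to compound 4 (0.04 log units; within the scatter), so the step stays within the scatter on this core as well. Set beside the earlier step, the change carries from one core to the other with no readable difference: the same change on two cores in this assay, a 1.0-fold lower number (0.01 log units; within the scatter) from compound 2 to compound 1 and a 1.1-fold lower number (0.04 log units; within the scatter) from compound 3 to compound 4, 1.1-fold (0.03 log units) apart, within the scatter of two such steps. Going by these compounds alone, this shows only that a step too small to read recurs on two cores in a single assay; it does not show that the methoxy has any effect on either core, nor that the same would hold on a third core.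

As far as these compounds go, all four compounds carry the nitro group on the aryl ketone ring, so it remains open whether the methoxy step would stay this small without it, for instance with a nitrile in its place. Also open, from the compounds shown here alone, is whether an amine, a carboxylic acid or a longer chain such as ethoxy on the same aromatic carbon would give a step beyond the scatter on either core.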